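Aryl piperazine carboxamides: swapping ring hydroxy for cyclopropyl

The source may hold more compounds than are shown below. What is called first, only, known or untested is meant among the compounds shown, and "the series" means these compounds.

Measured so far:
- compound 1 `COc1ccccc1N1CCN(CCCNc2nc(C)cc(C)c2C(N)=O)CC1`: 39.8 nM
- compound 2 `COc1ccccc1N1CCN(CCCOc2ccccc2C(=O)N(C)C)CC1`: 31.6 nM
- compound 3 `CN(C)C(=O)c1cccnc1NCCCN1CCN(c2ccccc2O)CC1`: 63.1 nM

All three numbers come from a functional assay on aorta for antagonist activity at Alpha-1D adrenergic receptor (Rattus norvegicus); a higher number here means weaker binding, a lower number tighter binding. Within the data shown here, compound 3 gives the highest of the three readings in this assay, but its distance to compound 1 and to compound 2 both sit within the usual scatter, so no order among the three can be claimed; the series so far reads as one flat cluster.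

Compound 4 `CN(C)C(=O)c1cccnc1NCCCN1CCN(c2ccccc2C2CC2)CC1` keeps the core of compound 3 and changes one site on the aryl ring attached to the piperazine:
cyclopropyl in place of hydroxy on an aromatic carbon
Among the measured compounds shown here, no measured pair in the set varies this site alone, so there is no step to lean on. The spread across compounds 1 to 3, all within scatter of one another while differing elsewhere, suggests tolerance to changes in this region.

The expected step of a 1.4-fold lower number from compound 3 to compound 4 (0.15 log units; within the scatter) is small and not beyond the scatter. Compound 4 is expected to give 45 nM, within 12 nM to 160 nM.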

Compound 4, dissociation constant: 63.1 nM
Beside the measured number, compound 4's estimate is 1.4-fold (0.15 log units) below it; low and high end bracket the measured number.
By their numbers in this assay, from the lowest: compounds 2, 1, 3 and 4 (each within the scatter of the next).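

In this assay, among these compounds, the exchange of hydroxy for cyclopropyl gives no change at the digits printed from compound 3 to compound 4 (within the scatter), which is the first single-site step at this aromatic carbon. The 2-hydroxyphenyl to 2-cyclopropylphenyl change removes the hydrogen-bond donor and acceptor of hydroxy and adds a three-membered ring of carbon, yet the reading holds, so within this pair the hydroxy is not needed to keep the value. Nothing measured here bears on why the two groups read alike.

On these data alone, whether this tolerance extends to an amine, a carboxylic acid or a longer alkyl chain at the same aromatic carbon remains open. As far as these compounds go, this is also a single step on one core, so it remains open whether cyclopropyl reads the same way on the cores of compound 1 and compound 2.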